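Stereochemical variation on a bicyclic thiadiazole series

The source may hold more compounds than are shown below. What is called first, only, known or untested is meant among the compounds shown, and "the series" means these compounds.

Two enantiomeric compounds have been tested in a functional assay on the whole organism for inhibition, with Rattus norvegicus as the target; on this read-out higher numbers stand for an effect only at larger amounts of compound and lower numbers for an effect already at smaller amounts. Within the data shown here, compound 1 `CCCSc1nsnc1[C@H]1CN2CCC[C@@H]1C2` gives 0.013 mg/kg, and compound 2 `CCCSc1nsnc1[C@@H]1CN2CCC[C@H]1C2` gives 0.03 mg/kg, so compound 2 holds the higher of the two numbers, with compound 1 its only neighbour (a 2.3-fold higher number from compound 1 to compound 2 (0.36 log units; beyond the scatter)). Compound 3 `CCCSc1nsnc1[C@H]1CN2CCC[C@H]1C2` differs from compound 2 in a single stereo element: the two compounds have the same atoms and bonds; at least one stereo element is drawn with a configuration in one of them and without one in the other: 1 of 3 stereo elements differ; a stereocentre at a saturated ring carbon is drawn S in compound 2 and R in compound 3. Among the measured compounds shown here, no measured step matches this change: the one step available, from compound 1 to compound 2, inverts both ring stereocentres at once, and the evidence on it is confined to the fact that one of compounds 1 and 2 is drawn with a defined configuration and the other without, at the place where they differ. For the measured compounds named here, a single inversion gives a diastereomer rather than the mirror image, so the direction in this assay cannot be read off; the modest size of the measured step is the only guide. Compound 3 is therefore expected at about 0.06 mg/kg, within 0.012 mg/kg to 0.3 mg/kg, a step of a 2.0-fold higher number from compound 2 to compound 3 (0.30 log units; within the scatter), with wide uncertainty in both directions.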

Compound 3, dose for half-maximal effect: > 3 mg/kg
Compound 3: no number, only a limit (the forecaster's own chance of this, stated with the estimate: 10%); middle value at least 50-fold (1.69 log units) from the limit.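

Compound 3 is recorded in this assay only as a limit, > 3 mg/kg, and not as a number. Even so, inverting one ring stereocentre gives an at least 100-fold higher number from compound 2 to compound 3 (2.00 log units; beyond the scatter), and the same kind of single inversion gives an at least 230-fold higher number from compound 1 to compound 3 (2.36 log units; beyond the scatter), whereas inverting both ring stereocentres together gave only a 2.3-fold higher number from compound 1 to compound 2 (0.36 log units; beyond the scatter). Across these three compounds, the relative arrangement of the two ring stereocentres therefore counts for far more in this read-out than the choice between mirror images, which remains a modest difference.

On these data alone, how far the true value of compound 3 lies past its limit stays open. Also open, as far as these compounds go, is whether this dependence on configuration would persist with a longer chain, such as hexyl, on the sulfur.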